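The source may report more compounds than this note shows. Statements on the series, on what has been measured and on what is new or still open speak of the compounds shown alone.

Compound 1 `CNC(=O)c1ccccc1Oc1nc(Nc2cccc(Br)c2)ncc1Br`: 38700 nM
Compound 2 `CNC(=O)c1ccccc1Oc1nc(Nc2ccccc2OC)ncc1Br`: > 50000 nM (a limit of the assay, not a number)
Compound 3 `CNC(=O)c1ccccc1Oc1nc(Nc2cccc(C)c2)ncc1Br`: 16200 nM

In a functional assay on HL-60 cells (Homo sapiens) for antiproliferative activity, read by MTT assay, with a stated time of 24 h (a lower number here means a stronger inhibitor, a higher number a weaker inhibitor), compound 3 gives 16200 nM, the lower of the two true numbers in the set, and all three compounds sit at weak levels. The next variant is compound 4 `CNC(=O)c1ccccc1Oc1nc(Nc2cccc(C(F)(F)F)c2)ncc1Br`, with trifluoromethyl in place of methyl on an aromatic carbon.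

Within the data shown here, the most direct evidence is a 2.4-fold lower number from compound 1 to compound 3 (0.38 log units; beyond the scatter), the only measured change at this carbon, with methyl in place of bromo. The other step, an at least 3.0-fold lower number from compound 2 to compound 3 (0.48 log units; beyond the scatter), replaces 2-methoxyphenyl with 3-methylphenyl and so says less about this carbon. Among the measured compounds shown here, with compound 1 as the sole measured non-methyl group here, at 38700 nM, a modest step towards a higher number is expected, though one precedent gives weak support. The estimated step is a 1.7-fold higher number from compound 3 to compound 4 (0.24 log units; within the scatter). For compound 4 the expected value is 28000 nM, with an estimated range of 11000 nM to 50000 nM.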

Compound 4, half-maximal inhibitory concentration: 44000 nM
Compound 4: the middle estimate sits 1.6-fold (0.20 log units) below what was measured; the measured number falls inside the stated range.
By their numbers in this assay, from the lowest: compound 3; then compounds 1 and 4 (each within the scatter of the next). At a limit, above all of these: compound 2.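

In this assay, trifluoromethyl in place of methyl gives a 2.7-fold higher number from compound 3 to compound 4 (0.43 log units; beyond the scatter), so a second group at this aromatic carbon now stands apart from methyl, where bromo alone did before. Trifluoromethyl in place of bromo gives a 1.1-fold higher number from compound 1 to compound 4 (0.06 log units; within the scatter), so compound 1 and compound 4 cannot be told apart here, and among the three groups at this carbon only methyl gives a distinct, lower number. Compound 2 carries a limit and not a number, and it differs from these compounds on the ring as a whole rather than at this carbon alone: the limit of > 50000 nM in this assay, at which 1 of the 4 values shown sits.

On these data alone, whether any group at this carbon can bring the number well under that of compound 3, at 16200 nM, remains open. An amine, a carboxylic acid or a longer chain here would test whether methyl is the best of a wider range or only of these three.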